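The source may report more compounds than this note shows. Statements on the series, on what has been measured and on what is new or still open speak of the compounds shown alone.

For the measured compounds named here, in a functional assay on MCF7 cells (Homo sapiens) for antiproliferative activity, read by MTT assay (on this read-out higher numbers stand for weaker inhibition and lower numbers for stronger inhibition), compound 1 `NS(=O)(=O)c1ccc(/N=C2\NC(=O)/C(=C3/C(=O)Nc4ccc(Cl)cc43)S2)cc1` gives 3960 nM, the only true number so far. Compound 2 `NS(=O)(=O)c1cccc(/N=C2\NC(=O)/C(=C3/C(=O)Nc4ccc(Cl)cc43)S2)c1` reports only a limit, > 200000 nM. Compound 3 `NS(=O)(=O)c1cccc(/N=C2\NC(=O)/C(=C3/C(=O)Nc4ccc([N+](=O)[O-])cc43)S2)c1` also reports only a limit, > 200000 nM. Compound 4 `Cc1ccc2c(c1)/C(=C1/S/C(=N/c3ccc(S(N)(=O)=O)cc3)NC1=O)C(=O)N2` departs from compound 1 in a single place, (methyl in place of chloro on an aromatic carbon), with methyl in place of chloro on an aromatic carbon. Going by the values given here, only one measured step touches a swap at this carbon, a step that the two limits leave unreadable from compound 2 to compound 3, and it has no readable size, so it offers no guide. With nothing pointing either way, no change beyond the scatter is expected in this assay, and the expected step is a 1.1-fold higher number from compound 1 to compound 4 (0.06 log units; within the scatter). Compound 4 is estimated at 4500 nM, within an expected range of 1500 nM to 15000 nM.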

Compound 4, half-maximal inhibitory concentration: > 200000 nM
Compound 4: only a limit was reported; the forecaster's own chance of this, stated with the estimate: 8%; middle value at least 44-fold (1.64 log units) away from the limit.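

In this assay, replacing chloro with methyl at this aromatic carbon gives an at least 50-fold higher number from compound 1 to compound 4 (1.70 log units; beyond the scatter), so this position is sensitive to a swap of a single heavy atom, which the earlier pair of limits could not reveal. Compound 4 reports only a limit, so the true size of this step remains unknown, and that limit recurs across the series: the limit of > 200000 nM in this assay, at which 3 of the 4 values shown sit.

As far as these compounds go, whether activity on the core of compound 1 depends on chloro alone remains open. Bromo, fluoro or methoxy at this carbon would help to settle that.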